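Swapping the aryl group on a piperazine nitrogen

This account rests on a few compounds, and the source may have more. Where it says the series, first, only, none or still open, it means among the compounds named here.

Compound 1 `COC(=O)CC/C(C)=C/Cc1c(OC)c(C)c2c(c1OCC#CCN1CCN(c3ccc(C#N)cc3)CC1)C(=O)OC2`: > 50000 nM
Compound 2 `COC(=O)CC/C(C)=C/Cc1c(OC)c(C)c2c(c1OCC#CCN1CCC(C(=O)OC)CC1)C(=O)OC2`: 40500 nM
Compound 3 `CCCCNc1ccc(CC#CCOc2c(C/C=C(\C)CCC(=O)OC)c(OC)c(C)c3c2C(=O)OC3)cc1`: 6970 nM

Of the compounds shown here, three have been measured in a functional assay on A549 cells (Homo sapiens) for inhibition, read by sulforhodamine B assay; a higher number here means a weaker inhibitor, a lower number a stronger inhibitor. For compound 1 the assay reports only a limit, > 50000 nM. Compound 2 gives 40500 nM, and compound 3 gives 6970 nM. Among the measured compounds shown here, the single measured step, a 5.8-fold lower number from compound 2 to compound 3 (0.76 log units; beyond the scatter), puts 4-(butylamino)phenyl in place of 4-(methoxycarbonyl)piperidin-1-yl on a saturated chain carbon bound to a triple-bonded carbon. Compound 1 sits at the limit of > 50000 nM in this assay, at which 1 of the 3 values shown sits.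

Compound 4 `COC(=O)CC/C(C)=C/Cc1c(OC)c(C)c2c(c1OCC#CCN1CCN(c3ccccc3F)CC1)C(=O)OC2` differs from compound 1 on an amine nitrogen in a ring of the six-membered non-aromatic ring with 2 nitrogen: 2-fluorophenyl in place of 4-cyanophenyl on an amine nitrogen in a ring. For the measured compounds named here, no measured step touches this place, so the step from compound 2 to compound 3 gives no guide to the size or direction of this change. Since compound 1 gives only a limit, compound 4 is expected to remain weak and near that limit, an expected step of a number no higher from compound 1 to compound 4 (the limit leaves the size open). The estimate for compound 4 is 50000 nM, with a range from 15000 nM to 150000 nM.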

Compound 4, half-maximal inhibitory concentration: 45300 nM
The estimate for compound 4 lay 1.1-fold (0.04 log units) above the measured number; the measured number falls inside the stated range.
By their numbers in this assay, from the lowest: compound 3; then compounds 2 and 4 (each within the scatter of the next). At a limit, above all of these: compound 1.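

Compound 1 stands at a limit of the assay, not at a true number: the limit of > 50000 nM in this assay, at which 1 of the 4 values shown sits.

In this assay, putting 2-fluorophenyl in place of 4-cyanophenyl on this amine nitrogen in a ring gives an at least 1.1-fold lower number from compound 1 to compound 4 (0.04 log units; that floor lies within the scatter). Among the compounds shown here, this is the first real number for an aryl group at this place, and the step does not establish any change in strength from this swap.

The compounds shown leave open how far the true value of compound 1 lies from that of compound 4. They also do not tell how this amine nitrogen would respond to a 4-fluorophenyl group, a 4-methoxyphenyl group or a simple alkyl chain such as butyl in place of the aryl group.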